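Changing the Amine Group on a Shared Core

A few compounds are considered here, and "the series" means these few. Any claim that something is new, unique, unknown or untested is made for them only; others in the source may bear on it.

In a functional assay on MCF7 cells (Homo sapiens) for inhibition, read by MTT assay, with a stated time of 48 h, tested at 10 uM (a higher number here means more inhibition of growth at the concentration tested, a lower number less inhibition of growth), compound 3 (`CCOC(=O)N1CCN(Cc2c(O)c([C@H]3CCN(C)C[C@H]3O)c3oc(C)cc(=O)c3c2O)CC1`) gives 31%, a value within the scatter of the other two measured compounds: compound 1 (`Cc1cc(=O)c2c(O)c(CN3CCCC3CO)c(O)c([C@H]3CCN(C)C[C@H]3O)c2o1`) gives 22%, and compound 2 (`Cc1cc(=O)c2c(O)c(CN(C)CC(=O)O)c(O)c([C@H]3CCN(C)C[C@H]3O)c2o1`) gives 27%. Compound 4 (`Cc1cc(=O)c2c(O)c(CN3CC(O)CC3C(=O)O)c(O)c([C@H]3CCN(C)C[C@H]3O)c2o1`) places 2-carboxy-4-hydroxypyrrolidin-1-yl in place of 4-(ethoxycarbonyl)piperazin-1-yl on a saturated chain carbon bound to an aromatic carbon. Three measured changes at that place bear on this one: a number 9 percentage points higher from compound 1 to compound 3 (within the scatter), a number 4 percentage points higher from compound 2 to compound 3 (within the scatter) and a number 5 percentage points higher from compound 1 to compound 2 (within the scatter). All three stay within the scatter, so no step beyond the scatter is expected in this assay. The expected change is a number 6 percentage points lower from compound 3 to compound 4 (within the scatter). The estimate for compound 4 is 25%, with an expected range of 12% to 38%.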

Compound 4, percent growth inhibition at one concentration: 25%
For compound 4 middle estimate and measured number coincide at the digits printed, and the stated range covers the measured number.
By their numbers in this assay, from the lowest: compounds 1, 4, 2 and 3 (each within the scatter of the next).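

In this assay, 2-carboxy-4-hydroxypyrrolidin-1-yl on a saturated chain carbon bound to an aromatic carbon gives a number 6 percentage points lower from compound 3 to compound 4 (within the scatter), a number 2 percentage points lower from compound 2 to compound 4 (within the scatter) and a number 3 percentage points higher from compound 1 to compound 4 (within the scatter). This extends the earlier picture: among the four amine groups shown at this place, with five- and six-membered rings and an open chain, no step leaves the scatter. Nothing available explains this flat result.

As far as these compounds go, what remains open is whether any group at this place can move the number beyond the scatter, for example morpholine, dimethylamino or a longer alkyl chain ending in a primary amine.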